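Replacing the Aminoalkyl Amide by a Chloropyridyl Amide

The source may hold more compounds than are shown below. What is called first, only, known or untested is meant among the compounds shown, and "the series" means these compounds.

Compound 1 `C/C=C/C(=O)Nc1cccc(-c2nc3ccccc3s2)c1` gives > 25000 nM in an ADME assay on Raji cells (Homo sapiens) for inhibition, with a stated time of 72 h (on this read-out lower numbers stand for an effect already at smaller amounts and higher numbers for an effect only at larger amounts of compound), which is a limit of the assay and not a number.
Compound 2 `CN(C)CCC(=O)Nc1cccc(-c2nc3ccccc3s2)c1` gives > 25000 nM in this assay, again a limit rather than a number.

Compound 2 therefore stands at the limit of this assay, and the same is true of compound 1. Among the compounds with values here, the one step between measured compounds, a step that the two limits leave unreadable from compound 1 to compound 2, is unreadable because the limit of > 25000 nM in this assay, at which 2 of the 2 values shown sit, covers both values. The new compound 3 `O=C(Nc1cccc(-c2nc3ccccc3s2)c1)c1ccncc1Cl` differs from compound 2 by 3-chloropyridin-4-yl in place of 2-(dimethylamino)ethyl on a carbonyl carbon. Within the data shown here, no measured step involves a 3-chloropyridin-4-yl group, and the single step on record says nothing about its size or direction. On these numbers the expectation for compound 3 is that the assay will again most likely return a limit, with the estimate given as 25000 nM within 5000 nM to 100000 nM. The step this estimate means is expected to be a number no higher from compound 2 to compound 3 (the limit leaves the size open).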

Compound 3, half-maximal effective concentration: > 25000 nM
Compound 3: no number, only a limit; the forecaster's own chance of this, stated with the estimate: 70%; the middle value lies on the limit itself.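

No step can be read among compound 1, compound 2 and compound 3, because each of the three gives a limit and not a number: the limit of > 25000 nM in this assay, at which 3 of the 3 values shown sit. The compounds shown leave open whether any group on this carbonyl carbon of the shared core gives a measurable value in this assay at all.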